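A Nitro Group Enters Compound 3

A few compounds are considered here, and "the series" means these few. Any claim that something is new, unique, unknown or untested is made for them only; others in the source may bear on it.

Of the compounds shown here, three have been tested in an ADME assay on RAW264.7 cells (Mus musculus) for cytotoxicity, read by MTT assay, with a stated time of 48 h; on this read-out lower numbers stand for stronger inhibition and higher numbers for weaker inhibition. Compound 1 `COc1cc(NC(=O)c2ccc(Cl)c([N+](=O)[O-])c2)ccc1NS(=O)(=O)C(F)(F)F` reaches only the limit > 250000 nM. One change brings an at least 7.8-fold lower number from compound 1 to compound 2 (0.89 log units; beyond the scatter), so that compound 2 `O=C(Nc1ccc(NS(=O)(=O)C(F)(F)F)c(Cl)c1)c1ccc(Cl)c([N+](=O)[O-])c1` gives 31700 nM. Compound 3 `O=C(Nc1ccc(NS(=O)(=O)C(F)(F)F)c(F)c1)c1ccc(Cl)cc1` gives 3270 nM, the lowest number shown, while compound 2 gives 31700 nM. Compound 4 `O=C(Nc1ccc(NS(=O)(=O)C(F)(F)F)c(F)c1)c1ccc(Cl)c([N+](=O)[O-])c1` differs from compound 3 by a single change: nitro in place of hydrogen on an aromatic carbon. Among the compounds with values here, no measured step tests this change: the only measured step, an at least 7.8-fold lower number from compound 1 to compound 2 (0.89 log units; beyond the scatter), swaps a different group, and compound 2, which carries a nitro group, differs from compound 3 in more than one place. For compound 4 only a small step of a 1.2-fold higher number from compound 3 to compound 4 (0.09 log units; within the scatter) is therefore expected, and its value is estimated at 4000 nM, most likely between 1500 nM and 12000 nM.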

Compound 4, half-maximal inhibitory concentration: 188000 nM
Estimate against measurement, compound 4: 47-fold (1.67 log units) below; the whole stated range lies below it.
By their numbers in this assay, from the lowest: compound 3; then compound 2; then compound 4. At a limit, above all of these: compound 1.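

In this assay, nitro in place of hydrogen on an aromatic carbon, ortho to a chloro group, gives a large step: a 57-fold higher number from compound 3 to compound 4 (1.76 log units; beyond the scatter). With the nitro group kept, the other ring also matters, as fluoro in place of chloro gives a 5.9-fold higher number from compound 2 to compound 4 (0.77 log units; beyond the scatter). Fluoro in place of methoxy gives an at least 1.3-fold lower number from compound 1 to compound 4 (0.12 log units; that floor lies within the scatter). That step is only a floor, as the value of compound 1 is a limit: the limit of > 250000 nM in this assay, at which 1 of the 4 values shown sits.

Still open, going by these compounds, is whether an amine or a carboxylic acid on this carbon would shift the number as nitro does. Also open, on these data alone, is whether nitro would give a similar step with chloro in place of fluoro.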